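Ester variation on a phenol-diene series: cytotoxicity notes

The source may report more compounds than this note shows. Statements on the series, on what has been measured and on what is new or still open speak of the compounds shown alone.

Measured in a functional assay on Raji cells (Homo sapiens) for cytotoxicity, with a stated time of 72 h; on this read-out lower numbers stand for an effect already at smaller amounts and higher numbers for an effect only at larger amounts of compound:
- Compound 1 `C=C[C@@](C)(/C=C/c1ccc(O)cc1)CC/C=C/C(=O)OCC` gives > 26000 nM, which is a limit of the assay and not a number.
- Compound 2 `C=C[C@@](C)(/C=C/c1ccc(O)cc1)CC/C=C/C(=O)OCc1ccccc1` gives > 26000 nM, again a limit of the assay.
- Compound 3 `C=C[C@@](C)(/C=C/c1ccc(O)c(/C=C/C(=O)OCC)c1)CCC=C(C)C` gives > 26000 nM, also a limit of the assay.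

From compound 1 to compound 2 the change is phenyl in place of methyl on a saturated chain carbon bound to an oxygen next to a carbonyl group. In this assay that step reads as a step that the two limits leave unreadable from compound 1 to compound 2, both values sitting at the limit of > 26000 nM in this assay, at which 3 of the 3 values shown sit. Compound 3 carries a different core from compound 1; that difference is not broken down here. Compound 4 `C=C[C@@](C)(/C=C/c1ccc(O)c(/C=C/C(=O)OCc2ccccc2)c1)CCC=C(C)C` is not yet measured and differs from compound 3 by phenyl in place of methyl on a saturated chain carbon bound to an oxygen next to a carbonyl group, the same change as between compound 1 and compound 2, at the same place.

For compound 4 the step is estimated as a step that the limit leaves unreadable from compound 3 to compound 4, resting on the parallel change that in this assay read as a step that the two limits leave unreadable from compound 1 to compound 2. Compound 4 is therefore expected near 50000 nM, between 15000 nM and 200000 nM, and most likely the assay will again report only a limit.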

Compound 4, half-maximal effective concentration: > 26000 nM
Compound 4: no number, only a limit; the forecaster's own chance of this, stated with the estimate: 85%; the middle value does not contradict the limit.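

Compound 3 and compound 4 both give only a limit in this assay, so no step can be read between them: the limit of > 26000 nM in this assay, at which 4 of the 4 values shown sit. The size of the ethyl to benzyl change on either core stays open; no compound shown gives a number.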